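The compounds below may be only part of what the source reports. "The series", "measured", "known", "first", "only" and "open" are said of these compounds alone.

Measured in an ADME assay on Vero cells (Chlorocebus sabaeus) for cytotoxicity, read by MTT assay, with a stated time of 48 h; a lower number here means a stronger inhibitor, a higher number a weaker inhibitor:
- compound 1 `Cc1ccc(C(=O)OC2CCC(CN3CCN(c4cc(=O)c5cc(C(F)(F)F)cc([N+](=O)[O-])c5s4)CC3)CC2)cc1`: > 64 ug/mL
- compound 2 `C=CC(=O)OC1CCC(CN2CCN(c3cc(=O)c4cc(C(F)(F)F)cc([N+](=O)[O-])c4s3)CC2)CC1`: > 64 ug/mL
- compound 3 `O=c1cc(N2CCN(CC3CCC(OS(=O)(=O)c4ccccc4)CC3)CC2)sc2c([N+](=O)[O-])cc(C(F)(F)F)cc12`: > 64 ug/mL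

Compound 3 gives > 64 ug/mL, which is a limit and not a number. Within the data shown here, the series so far shows (the limit of > 64 ug/mL in this assay, at which 3 of the 3 values shown sit).

Compound 4 `O=C(OC1CCC(CN2CCN(c3cc(=O)c4cc(C(F)(F)F)cc([N+](=O)[O-])c4s3)CC2)CC1)c1cccs1` differs by (thiophen-2-yl)carbonyl in place of phenylsulfonyl on an oxygen on a saturated carbon.

The measured steps that bear on this change are a step that the two limits leave unreadable from compound 1 to compound 3, a step that the two limits leave unreadable from compound 2 to compound 3 and a step that the two limits leave unreadable from compound 1 to compound 2. None of them has a readable size, so they give no direction. Compound 1 also has a carbonyl on that oxygen and gives > 64 ug/mL, again a limit.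

No step beyond the scatter is therefore expected in this assay, and the estimated step reads a step that the limit leaves unreadable from compound 3 to compound 4. A further limit is the most likely report. For compound 4 the expected value is 80 ug/mL, with an estimated range of 40 ug/mL to 160 ug/mL.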

Compound 4, half-maximal inhibitory concentration: > 64 ug/mL
Compound 4 ended at the assay's limit; the forecaster's own chance of this, stated with the estimate: 85%; the middle value lies beyond the limit too.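

In this assay compound 4 gives > 64 ug/mL, a limit and not a number, so no step among compound 1, compound 2, compound 3 and compound 4 can be read: the limit of > 64 ug/mL in this assay, at which 4 of the 4 values shown sit.

The compounds shown leave open whether (thiophen-2-yl)carbonyl, phenylsulfonyl, vinylcarbonyl and (4-methylphenyl)carbonyl on an oxygen on a saturated carbon differ at all in this assay.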